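This account rests on a few compounds, and the source may have more. Where it says the series, first, only, none or still open, it means among the compounds named here.

Compound 1 `COc1ccc(Oc2ccccc2-c2ccsc2S(=O)(=O)N2CCN(C(=O)Nc3ccc([N+](=O)[O-])cc3)CC2)cc1OC` — > 50000 nM
Compound 2 `O=C(NCCNS(=O)(=O)c1ccc(-c2ccccc2Oc2ccc(O)c(O)c2)s1)Nc1cc(Cl)cc(Cl)c1` — 10400 nM
Compound 3 `O=C(NCCNS(=O)(=O)c1cc(-c2ccccc2Oc2ccc(O)c(O)c2)cs1)Nc1cc(C(F)(F)F)cc(C(F)(F)F)c1` — 1300 nM

In a functional assay on HL-60 cells (Homo sapiens) for inhibition, read by CCK-8 assay, with a stated time of 48 h (a lower number here means a stronger inhibitor, a higher number a weaker inhibitor), compound 1 gives > 50000 nM, which is a limit of the assay and not a number. Within the data shown here, it is the one value sitting at the limit of > 50000 nM in this assay, at which 1 of the 3 values shown sits. Compound 2 gives 10400 nM in this assay, and compound 3 gives 1300 nM; both of these are numbers. Among the measured compounds shown here, no two of the measured compounds differ in only one place, so no measured step tells how a single change shifts the result here.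

Compound 4 `COc1ccc(Oc2ccc([N+](=O)[O-])cc2-c2ccsc2S(=O)(=O)N2CCN(C(=O)Nc3ccc([N+](=O)[O-])cc3)CC2)cc1OC` has not yet been measured. It differs from compound 1 in one place: nitro in place of hydrogen on an aromatic carbon. Because compound 1 stands at the limit of > 50000 nM in this assay, at which 1 of the 3 values shown sits, the step expected from this change is set at none beyond the scatter, with the estimate kept near the limit: an at least 1.2-fold lower number from compound 1 to compound 4 (0.09 log units; that floor lies within the scatter). Compound 4 is therefore expected to give about 40000 nM in this assay, with a likely range from 8000 nM to 200000 nM.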

Compound 4, half-maximal inhibitory concentration: > 50000 nM
Compound 4 was reported as a limit; the forecaster's own chance of this, stated with the estimate: 60%; at least 1.2-fold (0.09 log units) between middle value and limit.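

In this assay, compound 1 and compound 4 are each reported only as a limit, not a number, so no step for the added nitro can be read from this pair: the limit of > 50000 nM in this assay, at which 2 of the 4 values shown sit.

The compounds shown leave open whether nitro in place of hydrogen changes the result at all, and in which direction.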